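The compounds below may be only part of what the source reports. "The series", "measured", "known", "first", "only" and "open" are said of these compounds alone.

Measured so far in a functional assay for activation of Alpha-1D adrenergic receptor (Homo sapiens); a lower number here means that less compound is needed, a higher number that more compound is needed for the effect:
- Compound 1, `c1coc(-c2ccccc2NCC2=NCCN2)c1`: 16.2 nM.
- Compound 2, `Cc1nc(-c2ccccc2NCC2=NCCN2)cs1`: a limit of this assay, < 5020 nM.
- Compound 3, `c1csc(-c2ccccc2NCC2=NCCN2)c1`: 18.2 nM.

Compound 3 holds the higher of the two readable numbers, but its nearest neighbour is compound 1, and the step of a 1.1-fold higher number from compound 1 to compound 3 (0.05 log units; within the scatter) shows the two as indistinguishable; the third value is a limit only.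

Compound 4, `Cc1nc(-c2ccccc2NCC2=NCCN2)co1`, differs from compound 3 by 2-methyl-1,3-oxazol-4-yl in place of thiophen-2-yl on an aromatic carbon. Two kinds of evidence bear on this. First, the exchange of one five-membered ring with a single hetero atom for another, a 1.1-fold higher number from compound 1 to compound 3 (0.05 log units; within the scatter), cost nothing. Second, the only compound carrying a 2-methyl-1,3-azol-4-yl group, compound 2, reached only the limit (the limit of < 5020 nM in this assay, at which 1 of the 3 values shown sits), so the steps a step that the limit leaves unreadable from compound 1 to compound 2 and a step that the limit leaves unreadable from compound 2 to compound 3 cannot be sized, yet both point toward a much higher number. Compound 4 carries the oxygen counterpart of the group in compound 2, and the expected step of a 330-fold higher number from compound 3 to compound 4 (2.52 log units; beyond the scatter) is therefore a large rise, with a real chance that this assay again returns only a limit.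

For compound 4 the estimate in this assay is 6000 nM, within 1500 nM to 30000 nM.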

Compound 4, half-maximal effective concentration: < 5020 nM
Compound 4: only a limit was reported; the forecaster's own chance of this, stated with the estimate: 60%; middle value at least 1.1-fold (0.07 log units) from the limit.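

In this assay, among these compounds, compound 4 gives < 5020 nM, a limit and not a number, so no step linking compound 4 to compound 1, compound 2 or compound 3 can be read. Still open, from the compounds shown here alone, is the actual size of the numbers for 2-methyl-1,3-oxazol-4-yl in compound 4 and 2-methyl-1,3-thiazol-4-yl in compound 2.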